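Nitro in Place of Fluoro: Expected Cytotoxicity of Compound 4

The source may report more compounds than this note shows. Statements on the series, on what has been measured and on what is new or still open speak of the compounds shown alone.

Measured in an ADME assay on HeLa cells (Homo sapiens) for cytotoxicity, read by MTT assay, with a stated time of 72 h; on this read-out higher numbers stand for lower toxicity in this test and lower numbers for higher toxicity in this test:
Compound 1 `Clc1ccc(/C=N/c2sc3c(c2-c2nc4ccccc4s2)CCCC3)cc1` gives 431 ug/mL.
Compound 2 `Clc1ccc(/C=N/c2sc3c(c2-c2nc4ccccc4s2)CCCC3)c(Cl)c1` gives 542 ug/mL.
Compound 3 `Fc1ccccc1/C=N/c1sc2c(c1-c1nc3ccccc3s1)CCCC2` gives 426 ug/mL.

All three numbers lie within the scatter of one another: a 1.0-fold lower number from compound 1 to compound 3 (0.01 log units; within the scatter), and a 1.3-fold lower number from compound 2 to compound 3 (0.10 log units; within the scatter). Compound 3 therefore cannot be set apart from compound 1 or compound 2 on this read-out.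

The next compound, compound 4 `O=[N+]([O-])c1ccccc1/C=N/c1sc2c(c1-c1nc3ccccc3s1)CCCC2`, differs from compound 3 in one place: nitro in place of fluoro on an aromatic carbon.

The measured steps that bear on this change are all substituent swaps on the same aryl ring. Adding a chloro gave a 1.3-fold higher number from compound 1 to compound 2 (0.10 log units; within the scatter); exchanging 4-chlorophenyl for 2-fluorophenyl gave a 1.0-fold lower number from compound 1 to compound 3 (0.01 log units; within the scatter); exchanging 2,4-dichlorophenyl for 2-fluorophenyl gave a 1.3-fold lower number from compound 2 to compound 3 (0.10 log units; within the scatter). None of these moved this assay beyond the scatter. Among the compounds with values here, no measured step involves a nitro group, so the expectation rests on the indifference of this read-out to the three aryl substitutions seen so far.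

Compound 4 is accordingly expected to show no step beyond the scatter, a 1.0-fold higher number from compound 3 to compound 4 (0.00 log units; within the scatter). The estimate for compound 4 in this assay is 430 ug/mL, with a range from 200 ug/mL to 900 ug/mL.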

Compound 4, half-maximal cytotoxic concentration: 369 ug/mL
Compound 4: middle estimate off by 1.2-fold (0.07 log units), on the high side; measured number inside the range.
By their numbers in this assay, from the lowest: compounds 4, 3, 1 and 2 (each within the scatter of the next).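

On this assay, the place ortho to a large group now carries nitro, which, unlike the fluoro it replaces, brings hydrogen-bond acceptors and a double bond outside aromatic rings, yet the number does not move beyond the scatter (a 1.2-fold lower number from compound 3 to compound 4 (0.06 log units; within the scatter)). The result is the same when compound 4 is set against the two chlorinated compounds (a 1.2-fold lower number from compound 1 to compound 4 (0.07 log units; within the scatter); a 1.5-fold lower number from compound 2 to compound 4 (0.17 log units; within the scatter)), so 2-nitrophenyl cannot be told apart from 4-chlorophenyl, 2,4-dichlorophenyl or 2-fluorophenyl on this read-out. Nothing available explains why these exchanges leave the number within the scatter.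

The four compounds leave open whether any change on this aryl ring can move this assay beyond the scatter, for instance an amine or a carboxylic acid at the same place, or a longer chain such as butoxy. They also leave open whether the flat result holds for other cores, since all four compounds share one core and differ only in the aryl group.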